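Fluorophenyl hydrazide series: shifting the fluorine position

The compounds below may be only part of what the source reports. "The series", "measured", "known", "first", "only" and "open" are said of these compounds alone.

Measured so far in a functional assay on A549 cells (Homo sapiens) for antiproliferative activity, read by MTT assay, with a stated time of 24 h; a lower number here means a stronger inhibitor, a higher number a weaker inhibitor:
compound 1 `O=C(NNC(=O)c1ccccc1F)c1cccc(NS(=O)(=O)c2cnc(O)nc2O)c1` gives 10800 nM
compound 3 `O=C(NNC(=O)c1ccccc1NS(=O)(=O)c1cnc(O)nc1O)c1ccccc1F` gives 7150 nM
compound 2 `O=C(NNC(=O)c1cccc(NS(=O)(=O)c2cnc(O)nc2O)c1)c1ccc(F)cc1` gives only a limit of this assay, > 20000 nM

Compound 1 and compound 3 carry the same atoms joined differently; the difference between the two cores is not broken down here. Their two values lie within the scatter of each other. Compound 2 arises from compound 1 by 4-fluorophenyl in place of 2-fluorophenyl on a carbonyl carbon; this gave an at least 1.8-fold higher number from compound 1 to compound 2 (0.26 log units; that floor lies within the scatter). The value of compound 2 sits at the limit of > 20000 nM in this assay, at which 1 of the 3 values shown sits.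

Compound 4 `O=C(NNC(=O)c1ccccc1NS(=O)(=O)c1cnc(O)nc1O)c1ccc(F)cc1` is not yet measured; it arises from compound 3 by the same change, (4-fluorophenyl in place of 2-fluorophenyl on a carbonyl carbon), at the same place. A weakening of similar size is expected for compound 4, a 2.2-fold higher number from compound 3 to compound 4 (0.35 log units; beyond the scatter), resting on an at least 1.8-fold higher number from compound 1 to compound 2 (0.26 log units; that floor lies within the scatter). Compound 4 is therefore estimated near 16000 nM, between 8000 nM and 40000 nM, with a fair chance that this assay again returns only a limit.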

Compound 4, half-maximal inhibitory concentration: > 20000 nM
Compound 4 gave a limit, no number; the forecaster's own chance of this, stated with the estimate: 40%; at least 1.2-fold (0.09 log units) between middle value and limit.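

In this assay, 4-fluorophenyl in place of 2-fluorophenyl on a carbonyl carbon gives an at least 2.7-fold higher number from compound 3 to compound 4 (0.44 log units; beyond the scatter). Compound 2 and compound 4 each return only a limit, so neither step has a full size, and the comparison across the two cores stays open: the same change on two cores in this assay, an at least 1.8-fold higher number (0.26 log units; that floor lies within the scatter) from compound 1 to compound 2 and an at least 2.7-fold higher number (0.44 log units; beyond the scatter) from compound 3 to compound 4; the limit leaves it open whether they differ The change points the same way on both cores, but only the step on the core of compound 3 is beyond the scatter, and equal size on the two cores is not shown.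

The compounds shown leave open how a plain phenyl, or an amine or a methoxy group in place of the fluorine, would read. They also leave open the size of either step, since compound 2 and compound 4 give no number.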